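A Trimethoxyphenyl Variant of Compound 3

The source may report more compounds than this note shows. Statements on the series, on what has been measured and on what is new or still open speak of the compounds shown alone.

Measured so far:
compound 1, `CSc1nc(NCCCNc2ccnc3cc(Cl)ccc23)c(C#N)c(-c2ccccc2)n1`, 11000 nM
compound 2, `CSc1nc(OCCCNc2ccnc3cc(Cl)ccc23)c(C#N)c(-c2ccccc2)n1`, 3400 nM
compound 3, `CSc1nc(NCCCCNc2ccnc3cc(Cl)ccc23)c(C#N)c(-c2ccc([N+](=O)[O-])cc2)n1`, 890 nM

In an ADME assay on HeLa cells (Homo sapiens) for inhibition, read by cell counting (a higher number here means a weaker inhibitor, a lower number a stronger inhibitor), compound 3 gives the lowest of the three numbers. Compound 2 sits higher by a margin beyond the scatter, and compound 1 higher still, so compound 3 is the strongest inhibitor of the three on these numbers. Compounds 1 and 2 both differ from compound 3 in more than one place, so none of the three pairs shows the effect of a single change.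

Compound 4, `COc1cc(-c2nc(SC)nc(NCCCCNc3ccnc4cc(Cl)ccc34)c2C#N)cc(OC)c1OC`, is the next compound to be measured. It differs from compound 3 by 3,4,5-trimethoxyphenyl in place of 4-nitrophenyl on an aromatic carbon. Within the data shown here, nothing among the measured compounds shows what this exchange at this position does in this assay, so the direction of the step is open. A step of moderate size in either direction, or none beyond the scatter, is the reasonable expectation.

On that basis compound 4 is estimated to give 1000 nM in this assay, with a range from 250 nM to 4000 nM. This estimate corresponds to an expected step of a 1.1-fold higher number from compound 3 to compound 4 (0.05 log units; within the scatter).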

Compound 4, half-maximal inhibitory concentration: 3400 nM
Beside the measured number, compound 4's estimate is 3.4-fold (0.53 log units) below it; the range from low to high includes it.
By their numbers in this assay, from the lowest: compound 3; then compounds 2 and 4 (each within the scatter of the next); then compound 1.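

In this assay, among these compounds, the exchange of 4-nitrophenyl for 3,4,5-trimethoxyphenyl gives a 3.8-fold higher number from compound 3 to compound 4 (0.58 log units; beyond the scatter), and this is the first single change that can be read. It shows that the aromatic carbon next to the ring nitrogen and ortho to a cyano group is not indifferent to the group it carries: with the rest of the structure held the same, the compound with 4-nitrophenyl is the stronger inhibitor of this pair. The measurements shown include nothing that accounts for the size or direction of this step, so it stands as an observation about these two groups only.

On these data alone, what remains open is which part of the exchange matters, the loss of the nitro group or the arrival of the three methoxy groups, and a plain phenyl, a 4-methoxyphenyl or a 3,5-dimethoxyphenyl on the chain of compound 3 would help to separate the two. Also open, as far as these compounds go, are how an aminophenyl or a carboxyphenyl would behave at this position, and whether the same exchange gives a similar step on the shorter chain of compound 1.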